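This account rests on a few compounds, and the source may have more. Where it says the series, first, only, none or still open, it means among the compounds named here.

Compound 1 `O=C(C1CCN(c2ccncc2Br)CC1)N1CCN(S(=O)(=O)c2ccc(Br)cc2)CC1` carries 3-bromopyridin-4-yl on an amine nitrogen in a ring together with a (4-bromophenyl)sulfonyl group; in an assay for inhibition of lanosterol synthase (Rattus norvegicus), using microsomes, tested at 100 nM (a lower number here means less inhibition, a higher number more inhibition at the concentration tested (going by the name of the read-out)), compound 1 gives 89%. Compound 2 `O=C(C1CCN(c2ncncc2Br)CC1)N1CCN(S(=O)(=O)c2ccc(Br)cc2)CC1` has 5-bromopyrimidin-4-yl in that place, and in this assay compound 2 gives 47%. Among the compounds with values here, the only measured step in the set, a number 42 percentage points lower from compound 1 to compound 2 (beyond the scatter), concerns the ring on the amine nitrogen and leaves the sulfonyl aryl untouched. Compound 3 `O=C(N1CCC(c2ccncc2)CC1)N1CCN(S(=O)(=O)c2ccc(Cl)cc2)CC1`, with a (4-chlorophenyl)sulfonyl group, gives 91% in this assay; it stands highest of the three numbers, but its gap to compound 1 lies within the scatter, and only compound 2 sits clearly lower.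

Compound 4 `O=C(N1CCC(c2ccncc2)CC1)N1CCN(S(=O)(=O)c2ccc(Br)cc2)CC1` differs from compound 3 by bromo in place of chloro on an aromatic carbon. Within the data shown here, no measured pair isolates this exchange: compounds 1 and 3 differ at the sulfonyl aryl but also elsewhere, so their two values show only that both sit high. Among the measured compounds shown here, the one step that was measured does not touch the changed position and so gives no direct guide for the size or direction here. The expected step is a number 3 percentage points lower from compound 3 to compound 4 (within the scatter), that is, none beyond the scatter. Compound 4 is therefore estimated at 88%, with a range from 75% to 96%.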

Compound 4, a percentage reported as inhibition, at one concentration (the size of the read-out at that concentration, not a potency): 94%
Compound 4: middle estimate off by 6 percentage points, on the low side, and the stated range covers the measured number.
By their numbers in this assay, from the lowest: compound 2; then compounds 1, 3 and 4 (each within the scatter of the next).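

The exchange of chloro for bromo on an aromatic carbon para to a large group is now isolated in a single pair: in this assay the step is a number 3 percentage points higher from compound 3 to compound 4 (within the scatter), so on the core of compound 3 either halogen at this position gives high inhibition, with no difference that can be told from the scatter. Within the data shown here, the only step beyond the scatter in the set remains a number 42 percentage points lower from compound 1 to compound 2 (beyond the scatter), which lies at the ring on the amine nitrogen and not at the sulfonyl aryl. Nothing measured here accounts for this outcome at the halogen position.

The compounds shown speak only for chloro and bromo at this position, so what a methoxy group, a nitrile or a carboxylic acid would give there stays open. Both values also sit high at a single concentration, so any difference between the two halogens at lower concentrations is out of view, and whether the same exchange would read alike on the core of compound 1 is equally unanswered.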